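Swapping the anilino aryl group on a shared core

The source may report more compounds than this note shows. Statements on the series, on what has been measured and on what is new or still open speak of the compounds shown alone.

Compound 1 `COc1ccc(Nc2ncc(C(F)(F)F)c(N3Cc4cccc(N(C)S(C)(=O)=O)c4C3)n2)cc1C(F)(F)F` in a functional assay on A549 cells (Homo sapiens) for antiproliferative activity, read by spectrophotometry, with a stated time of 2 days (a lower number here means a stronger inhibitor of growth, a higher number a weaker inhibitor of growth), gives > 30000 nM, which is a limit of the assay. Compound 2 `CN(c1cccc2c1CN(c1nc(Nc3cc(Cl)cc(C(F)(F)F)c3)ncc1C(F)(F)F)C2)S(C)(=O)=O` gives 6700 nM. Compound 3 `Cc1ccc(Nc2ncc(C(F)(F)F)c(N3Cc4cccc(N(C)S(C)(=O)=O)c4C3)n2)cc1C` gives > 30000 nM, again a limit.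

Compound 3 therefore stands at the edge of what the assay reports, sharing that position with compound 1 (the limit of > 30000 nM in this assay, at which 2 of the 3 values shown sit). Going by the values given here, the one readable step toward it, an at least 4.4-fold higher number from compound 2 to compound 3 (0.65 log units; beyond the scatter), shows that the 3,4-dimethylphenyl group weakens growth inhibition relative to the 3-chloro-5-(trifluoromethyl)phenyl group, while a step that the two limits leave unreadable from compound 1 to compound 3 cannot be sized because both ends sit at the limit.

Compound 4 `Cc1cc(F)ccc1Nc1ncc(C(F)(F)F)c(N2Cc3cccc(N(C)S(C)(=O)=O)c3C2)n1` carries the change (4-fluoro-2-methylphenyl in place of 3,4-dimethylphenyl on a nitrogen on an aromatic ring). Among the compounds with values here, no measured step covers this exact exchange. The starting point is the limit. Any step toward weaker inhibition would go unseen, and only a sizeable gain would yield a number. The two readable comparisons, which reach a number only for compound 2, give no ground to expect such a gain from one unhalogenated aryl group to a lightly fluorinated one. Compound 4 is expected to remain near the limit, an estimated a number no higher from compound 3 to compound 4 (the limit leaves the size open) and a value of 30000 nM within 8000 nM to 100000 nM.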

Compound 4, concentration for 50% growth inhibition: > 30000 nM
Compound 4: only a limit was reported; the forecaster's own chance of this, stated with the estimate: 70%; the middle value sits exactly at the limit.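

Compound 4 joins compound 1 and compound 3 at the limit, so the exchange of 3,4-dimethylphenyl for 4-fluoro-2-methylphenyl adds a third aryl group that gives no number: the limit of > 30000 nM in this assay, at which 3 of the 4 values shown sit. The steps among these three compounds cannot be read, as both ends of each are limits, so any difference between these aryl groups stays hidden. Going by these compounds alone, the one readable step, an at least 4.4-fold higher number from compound 2 to compound 4 (0.65 log units; beyond the scatter), shows that 4-fluoro-2-methylphenyl, like 3,4-dimethylphenyl, falls short of 3-chloro-5-(trifluoromethyl)phenyl in this assay, and that a fluorine on this aryl group does not by itself bring a compound to a readable value.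

Compound 2 remains the only compound here with a number, so the compounds shown leave open which feature of its 3-chloro-5-(trifluoromethyl)phenyl group matters, given that the trifluoromethyl group of compound 1 comes with a limit. A dichlorophenyl group on the same nitrogen, or a phenyl group carrying a nitrile or an amine, would show whether other substituents on this aryl group can also give a value in this assay.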